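Working notes: amino group swap from compound 3 to compound 4

A few compounds are considered here, and "the series" means these few. Any claim that something is new, unique, unknown or untested is made for them only; others in the source may bear on it.

Values measured so far in a functional assay on MCF7 cells (Homo sapiens) for inhibition, read by MTT assay, with a stated time of 3 days (a higher number here means a weaker inhibitor, a lower number a stronger inhibitor), for the series
compound 1 `CC[C@H](C)[C@@H](NCC(=O)NNC(=O)COc1ccc(-c2nc3ccccc3s2)cc1OC)C(=O)O` gives 1790 nM
compound 2 `COc1cc(-c2nc3ccccc3s2)ccc1OCC(=O)NNC(=O)CN[C@@H](CCSC)C(=O)O` gives 1950 nM
compound 3 `CCOC(=O)CN(C)CC(=O)NNC(=O)COc1ccc(-c2nc3ccccc3s2)cc1OC` gives 1980 nM

Compound 3 at 1980 nM stands level with the other two compounds, as a 1.0-fold higher number from compound 2 to compound 3 (0.01 log units; within the scatter) and a 1.1-fold higher number from compound 1 to compound 3 (0.04 log units; within the scatter) show.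

The next compound is compound 4 `CCOC(=O)[C@H](CS)N(CC(=O)NNC(=O)COc1ccc(-c2nc3ccccc3s2)cc1OC)C(C)=O`, which carries acetyl(1-(ethoxycarbonyl)-2-sulfanylethyl)amino in place of ((ethoxycarbonyl)methyl)(methyl)amino on a saturated chain carbon bound to a carbonyl carbon. The change counts as acetyl(1-(ethoxycarbonyl)-2-sulfanylethyl)amino in place of ((ethoxycarbonyl)methyl)(methyl)amino on a saturated chain carbon bound to a carbonyl carbon and keeps the rest of the structure.

The measured steps bear on this change only in part. Those two steps and a 1.1-fold higher number from compound 1 to compound 2 (0.04 log units; within the scatter) all replace groups on the same amine nitrogen, and all three stay within the scatter. Among the compounds with values here, no measured compound carries an acetyl on that nitrogen or a free sulfanyl, so these two features are untested and the range below is kept wide.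

Taking a 1.1-fold higher number from compound 1 to compound 3 (0.04 log units; within the scatter) as the guide, no step beyond the scatter is expected in this assay in either direction. The expected step is a 1.0-fold lower number from compound 3 to compound 4 (0.02 log units; within the scatter). For compound 4 the estimated value is 1900 nM, with an expected range from 900 nM to 4000 nM.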

Compound 4, half-maximal inhibitory concentration: 1890 nM
For compound 4 the middle estimate is 1.0-fold (0.00 log units) above the measured one, within the range that was stated.
By their numbers in this assay, from the lowest: compounds 1, 4, 2 and 3 (each within the scatter of the next).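

Notes on the amine substituent: in this assay the step from the small tertiary amine to the acetylated one is small, with a 1.0-fold lower number from compound 3 to compound 4 (0.02 log units; within the scatter) lying within the scatter. The same holds against both compounds bearing a free carboxylic acid, with a 1.0-fold lower number from compound 2 to compound 4 (0.01 log units; within the scatter) and a 1.1-fold higher number from compound 1 to compound 4 (0.02 log units; within the scatter) also within the scatter, so this place on a saturated chain carbon bound to a carbonyl carbon now tolerates an acetyl on the nitrogen, a free sulfanyl and a group with more heavy atoms, without a step beyond the scatter. No supporting measurement bears on why these four compounds stand level.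

The acetyl and the sulfanyl enter together in compound 4, so their separate contributions stay unresolved, and a compound with only one of them would be needed to tell them apart. On these data alone, it also remains open whether this level holds for a ring on the nitrogen, such as a morpholine or a piperazine, for an unsubstituted primary amine, or for a longer chain ending in an amine.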